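Ester variation on a shared core in growth inhibition

This account rests on a few compounds, and the source may have more. Where it says the series, first, only, none or still open, it means among the compounds named here.

Measured compounds:
compound 1 `CC(=O)OCCCOC1(c2ccc(Cl)cc2)c2ccccc2C(=O)N1Cc1ccc(Cl)cc1` gives 68000 nM in a functional assay on HCT-116 cells (Homo sapiens) for inhibition, read by fluorescence, with a stated time of 48 h; on this read-out higher numbers stand for weaker inhibition of growth and lower numbers for stronger inhibition of growth
compound 2 `CC(=O)OCC(C)(C)COC1(c2ccc(Cl)cc2)c2ccccc2C(=O)N1Cc1ccc(Cl)cc1` gives 70000 nM in this assay

Compound 2 stands beside compound 1 on the numbers shown: the step of a 1.0-fold higher number from compound 1 to compound 2 (0.01 log units; within the scatter) is within the scatter, so neither compound is separated from the other. Compound 3 `CC(C)(COC(=O)[C@@H](N)c1ccccc1)COC1(c2ccc(Cl)cc2)c2ccccc2C(=O)N1Cc1ccc(Cl)cc1` differs from compound 2 by amino(phenyl)methyl in place of methyl on a carbonyl carbon. Within the data shown here, the only measured step, a 1.0-fold higher number from compound 1 to compound 2 (0.01 log units; within the scatter), concerns the saturated chain carbon bound to an oxygen on a saturated carbon, not the carbonyl carbon, and it was within the scatter; no measured step bears on the change from compound 2 to compound 3. With nothing to lean on, the number for compound 3 is expected to stay near that of compound 2, giving an expected step of a 1.4-fold lower number from compound 2 to compound 3 (0.15 log units; within the scatter) in this assay with a wide range. The estimate for compound 3 is 50000 nM, between 15000 nM and 150000 nM.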

Compound 3, concentration for 50% growth inhibition: 38000 nM
Compound 3: the middle estimate sits 1.3-fold (0.12 log units) above what was measured, and the stated range covers the measured number.
By their numbers in this assay, from the lowest: compounds 3, 1 and 2 (each within the scatter of the next).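

At the carbonyl carbon, amino(phenyl)methyl in place of methyl gives a 1.8-fold lower number from compound 2 to compound 3 (0.27 log units; within the scatter) in this assay, so compound 3 is not separated from compound 2. The earlier step concerned only the saturated chain carbon, whereas this one shows that a group of 8 heavy atoms, carrying a six-membered aromatic ring and a defined stereocentre, can stand on the carbonyl carbon with no change beyond the scatter. No measurement on hand explains the result or ties it to any feature of the entering group.

Going by these compounds, whether benzyl on the carbonyl carbon, which lacks the amine, would read the same as amino(phenyl)methyl remains open. Also open, on these data alone, is whether a longer chain or a carboxylic acid at this carbon would separate from compound 2.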